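Working notes: three measured compounds and one untested analogue

A few compounds are considered here, and "the series" means these few. Any claim that something is new, unique, unknown or untested is made for them only; others in the source may bear on it.

Measured so far:
compound 1 `Nc1scc(CN2CCN(c3ccc(OC(F)(F)F)cc3)CC2)c1C(=O)c1ccc(Cl)cc1` gives 0%
compound 2 `Nc1scc(CN2CCC(c3ccc(Cl)cc3)CC2)c1C(=O)c1ccc(Cl)cc1` gives 0%
compound 3 `Nc1scc(CN2CCN(c3ccc(C(F)(F)F)cc3)CC2)c1C(=O)c1cccc(C(F)(F)F)c1` gives 0%

All three readings come from an assay on CHO cells for displacement of a labelled ligand from adenosine receptor A1 (Homo sapiens), read by scintillation counting, with a stated time of 120 min, tested at 10 uM; on this read-out lower numbers stand for less inhibition and higher numbers for more inhibition at the one concentration tested (going by the name of the read-out). In this assay compound 1 gives 0%, and compounds 2 and 3 stand at the same digits, so no difference beyond the usual scatter of repeated measurements separates any of the three. The inhibition in this assay is level across the three on these numbers. Within the data shown here, no pair among the measured compounds differs in only one place, so no single-change step can be read off.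

Compound 4 `Nc1scc(CN2CCN(c3c(F)cccc3F)CC2)c1C(=O)c1ccc(Cl)cc1` has not yet been measured. Relative to compound 1 the change is 2,6-difluorophenyl in place of 4-(trifluoromethoxy)phenyl on an amine nitrogen in a ring. The rest of compound 1 is unchanged.

Among the measured compounds shown here, with every measured compound at the same reading and no step established in either direction, nothing in the data points to movement. The step from compound 1 to compound 4 is expected to be a number 2 percentage points higher from compound 1 to compound 4 (within the scatter), that is, none beyond the scatter. Compound 4 is estimated at 2%, with a range from 0% to 15%.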

Compound 4, a percentage reported as inhibition, at one concentration (the size of the read-out at that concentration, not a potency): 1%
The estimate for compound 4 lay 1 percentage points above the measured number; the measured number falls inside the stated range.
By their numbers in this assay, from the lowest: compounds 1, 2, 3 and 4 (each within the scatter of the next).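

In this assay, among these compounds, placing 2,6-difluorophenyl in place of 4-(trifluoromethoxy)phenyl on the amine nitrogen in the ring gives a number 1 percentage points higher from compound 1 to compound 4 (within the scatter), and this is the first single-change step that can be read. At this position, then, going from a group of 11 heavy atoms with 1 hydrogen-bond acceptor to one of 8 heavy atoms with 0 hydrogen-bond acceptors brings no change beyond the scatter, although both compounds sit at the low end of the read-out, so the step cannot show how this change would behave on a compound with clear inhibition. No available evidence bears on this result.

Going by these compounds, whether a different kind of group on this nitrogen, such as a pyridine ring, a carboxylic acid or a longer chain ending in an amine, would lift the reading remains open. Also open, on these data alone, is whether a change elsewhere on the shared core, for instance replacing the carbonyl or the free amine, would move the inhibition.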